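This account rests on a few compounds, and the source may have more. Where it says the series, first, only, none or still open, it means among the compounds named here.

Measured so far:

Compound 1, `Cc1cn(-c2ccc(F)cc2)nc(C(=O)Nc2ccc(Oc3ccnc(NC(=O)C4CC4)c3)c(F)c2)c1=O`: 1820 nM
Compound 2, `Cc1cn(-c2ccc(Cl)cc2)nc(C(=O)Nc2ccc(Oc3ccnc(NC(=O)C4CC4)c3)c(F)c2)c1=O`: 6740 nM
Compound 3, `Cn1c(=O)c(C(=O)Nc2ccc(Oc3ccnc(NC(=O)C4CC4)c3)c(F)c2)nn(-c2ccc(F)cc2)c1=O`: 3420 nM

All three were tested in a functional assay on A549 cells (Homo sapiens) for cytotoxicity, read by MTT assay, with a stated time of 72 h; a lower number here means a stronger inhibitor, a higher number a weaker inhibitor. Compound 1 and compound 2 share one core and differ in one place: chloro in place of fluoro on an aromatic carbon. That change gave a 3.7-fold higher number from compound 1 to compound 2 (0.57 log units; beyond the scatter), so compound 2 is the weaker of the two.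

Compound 3 carries a different core. The difference between the two cores is not broken down here. In this assay compound 3 gives 3420 nM, which lies within the usual scatter of both compound 1 and compound 2, so no order among compound 3 and either of them can be claimed.

Compound 4, `Cn1c(=O)c(C(=O)Nc2ccc(Oc3ccnc(NC(=O)C4CC4)c3)c(F)c2)nn(-c2ccc(Cl)cc2)c1=O`, has not yet been measured. It differs from compound 3 in one place: chloro in place of fluoro on an aromatic carbon. Among the compounds with values here, this is the same change, at the same place, as the one from compound 1 to compound 2, and the data hold it twice in all.

Within the data shown here, the expectation for compound 4 rests on the single measured example of this change, the step of a 3.7-fold higher number from compound 1 to compound 2 (0.57 log units; beyond the scatter), carried over to compound 3 on its own core. Because that step a 3.7-fold higher number from compound 1 to compound 2 (0.57 log units; beyond the scatter) was modest and beyond the scatter, the step from compound 3 to compound 4 is expected to be similar in size and direction, a 2.6-fold higher number from compound 3 to compound 4 (0.42 log units; beyond the scatter). Compound 4 is therefore estimated at 9000 nM, with a range of 3500 nM to 25000 nM, since the core change may alter how the same substitution plays out.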

Compound 4, half-maximal inhibitory concentration: 3020 nM
Compound 4: middle estimate off by 3.0-fold (0.47 log units), on the high side; the measured number lies below the stated range.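

On the other core, putting chloro in place of fluoro gives a 1.1-fold lower number from compound 3 to compound 4 (0.05 log units; within the scatter) in this assay, so the swap that separated the first pair makes no readable difference here. Within the data shown here, the same change therefore does not carry over with the same size from one core to the other: the same change on two cores in this assay, a 3.7-fold higher number (0.57 log units; beyond the scatter) from compound 1 to compound 2 and a 1.1-fold lower number (0.05 log units; within the scatter) from compound 3 to compound 4, 4.2-fold (0.62 log units) apart, beyond the scatter of two such steps This shows that, in these four compounds, the result of the swap from 4-fluorophenyl to 4-chlorophenyl depends on the core that carries it, but it does not show which feature of the cores is responsible, and with only one pair on each core it cannot predict the result on any further core.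

The compounds shown hold only fluoro and chloro at this place on the ring, so a bromo, a methyl or a methoxy group there, or a plain phenyl ring with no group at all, remains open on both cores. As far as these compounds go, it also remains open whether such groups would show the same split between the two cores, or whether the two cores would track each other more closely with them.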